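From Methoxy to Chloro on the Shared Core

This account rests on a few compounds, and the source may have more. Where it says the series, first, only, none or still open, it means among the compounds named here.

Compound 1 `OC(CCn1nc2c(Br)c(Br)c(Br)c(Br)c2n1)c1cccc(Br)c1` gives 0% in a functional assay on MCF7 cells (Homo sapiens) for antiproliferative activity, read by MTT assay, with a stated time of 48 h, tested at 100 uM; on this read-out higher numbers stand for a weaker effect at the one concentration tested and lower numbers for a stronger effect.
Compound 2 `OC(CCn1nc2c(Br)c(Br)c(Br)c(Br)c2n1)c1ccc(F)cc1` gives 0%.
Compound 3 `COc1cccc(C(O)CCn2nc3c(Br)c(Br)c(Br)c(Br)c3n2)c1` gives 6%.

All three share one core and differ only in the aromatic ring at the end of the chain. Compound 3 has the top number of the three, but the step of a number 6 percentage points higher from compound 1 to compound 3 (within the scatter) and the step of a number 6 percentage points higher from compound 2 to compound 3 (within the scatter) both lie within the scatter, so the three compounds cannot be told apart on these numbers.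

Compound 4 `OC(CCn1nc2c(Br)c(Br)c(Br)c(Br)c2n1)c1cccc(Cl)c1` differs from compound 3 by chloro in place of methoxy on an aromatic carbon. Among the compounds with values here, the closest precedent is the reverse exchange, bromo for methoxy at the same aromatic carbon, seen as a number 6 percentage points higher from compound 1 to compound 3 (within the scatter); the aryl swap no change at the digits printed from compound 1 to compound 2 (within the scatter) also moved nothing. Both steps stayed within the scatter, so no step beyond the scatter is expected for compound 4 in this assay, and the expected step is a number 3 percentage points lower from compound 3 to compound 4 (within the scatter). Compound 4 is therefore expected to give about 3%, between 0% and 14%.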

Compound 4, a percentage reported as activity, at one concentration (the size of the read-out at that concentration, not a potency): 0.5%
For compound 4 the middle estimate is 2.5 percentage points above the measured one; the measured number falls inside the stated range.
By their numbers in this assay, from the lowest: compounds 1, 2, 4 and 3 (each within the scatter of the next).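

Replacing the methoxy with chloro on this aromatic carbon removes the one hydrogen-bond acceptor in that group and one heavy atom, yet in this assay the result is still only a small shift (a number 5.5 percentage points lower from compound 3 to compound 4 (within the scatter)). Chloro also fails to separate from the other two aryl end groups, both against bromo on the same carbon (a number 0.5 percentage points higher from compound 1 to compound 4 (within the scatter)) and against the 4-fluorophenyl end (a number 0.5 percentage points higher from compound 2 to compound 4 (within the scatter)), so all four compounds now stand within the scatter of one another. Nothing measured here explains why these exchanges leave the number so little changed.

Still open, from the compounds shown here alone, is whether an amine or a carboxylic acid on this aromatic carbon would give a step beyond the scatter. A longer chain between the shared core and the aromatic ring is equally untested by these compounds.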